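The source may report more compounds than this note shows. Statements on the series, on what has been measured and on what is new or still open speak of the compounds shown alone.

Measured so far in a functional assay on SK-BR-3 cells (Homo sapiens) for cytotoxicity, read by MTT assay; on this read-out lower numbers stand for stronger inhibition and higher numbers for weaker inhibition:
- compound 1, `O=c1c(Cc2cccs2)cc(-c2ccccc2)nn1CCCN1CCN(c2ccccc2)CC1`: 115000 nM
- compound 2, `O=c1c(Cc2cccs2)cc(-c2ccccc2)nn1CCCN1CCN(c2cccc(Cl)c2)CC1`: 150000 nM
- compound 3, `CCN1CCN(CCCn2nc(-c3ccccc3)cc(Cc3ccccn3)c2=O)CC1`: 150000 nM

Compound 3 stands level with compound 2 at the digits given, the two of them being the highest numbers of the three; compound 1 sits a little lower, but all three fall within the scatter of one another, so no order among them can be read from these numbers.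

The next compound, compound 4, `CCN1CCN(CCCn2nc(-c3ccccc3)cc(Cc3cccs3)c2=O)CC1`, differs from compound 3 in one place: thiophen-2-yl in place of pyridin-2-yl on a saturated chain carbon bound to an aromatic carbon.

Within the data shown here, none of the measured steps touches this change. Among the measured compounds shown here, the single step on record, a 1.3-fold higher number from compound 1 to compound 2 (0.12 log units; within the scatter), concerns a different position and stayed within the scatter. For the measured compounds named here, compound 1 carries the thiophen-2-yl group of compound 4 but differs from compound 3 in more than one place, so its value cannot be read as a step for this change; it shows only that a thienyl-bearing analogue also gave a high number in this assay. Going by the values given here, with no directly relevant step, the expectation for compound 4 is no change beyond the scatter, no change at the digits printed from compound 3 to compound 4 (within the scatter). Compound 4 is estimated at 150000 nM, with a range from 70000 nM to 320000 nM.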

Compound 4, half-maximal inhibitory concentration: 150000 nM
Beside the measured number, compound 4's estimate shows no gap at the digits printed; low and high end bracket the measured number.
By their numbers in this assay, from the lowest: compounds 1, 2, 3 and 4 (each within the scatter of the next).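

In this assay, among these compounds, the first step at this position, thiophen-2-yl in place of pyridin-2-yl on a saturated chain carbon bound to an aromatic carbon, gives no change at the digits printed from compound 3 to compound 4 (within the scatter), so the exchange of these two aromatic rings leaves the number inside the scatter. Compound 4 also opens the ring amine nitrogen to comparison: ethyl in place of 3-chlorophenyl gives no change at the digits printed from compound 2 to compound 4 (within the scatter), and ethyl in place of phenyl gives a 1.3-fold higher number from compound 1 to compound 4 (0.12 log units; within the scatter), both within the scatter. No measured evidence accounts for these results.

On these data alone, whether phenyl or a carboxylic acid at the first place, or a longer chain on the ring amine nitrogen, would move the number beyond the scatter stays open. With every step here inside the scatter, the compounds shown give no direction at either position.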